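Thiophene methyl position in the acrylophenone series

The source may hold more compounds than are shown below. What is called first, only, known or untested is meant among the compounds shown, and "the series" means these compounds.

Measured so far in a functional assay on HUVEC cells (Homo sapiens), read by BrdU incorporation, with a stated time of 72 h; a lower number here means a stronger inhibitor, a higher number a weaker inhibitor:
- compound 1 `Cc1ccc2nc(Cl)c(/C=C/C(=O)c3sccc3C)cc2c1`, 127 nM
- compound 2 `Cc1cccc2cc(/C=C/C(=O)c3ccc(I)s3)c(Cl)nc12`, 284 nM

Compound 1 gives the lower of the two numbers in this assay, and its gap to compound 2 lies beyond the usual scatter.

The next step is compound 3 `Cc1ccc2nc(Cl)c(/C=C/C(=O)c3ccc(C)s3)cc2c1`. Against compound 1 the change is 5-methylthiophen-2-yl in place of 3-methylthiophen-2-yl on a carbonyl carbon. Going by the values given here, no measured pair in the set isolates this change, so its size is unknown; with the same atoms joined differently and only compound 2 for comparison, no shift beyond the scatter is expected in either direction.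

Compound 3 is therefore expected near compound 1, estimated at 150 nM (range 60 nM to 400 nM), a step of a 1.2-fold higher number from compound 1 to compound 3 (0.07 log units; within the scatter).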

Compound 3, half-maximal inhibitory concentration: 128 nM
Compound 3: middle estimate off by 1.2-fold (0.07 log units), on the high side, and the stated range covers the measured number.
By their numbers in this assay, from the lowest: compounds 1 and 3 (each within the scatter of the next); then compound 2.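

Going by these compounds alone, replacing 3-methylthiophen-2-yl with 5-methylthiophen-2-yl on the carbonyl carbon gives a 1.0-fold higher number from compound 1 to compound 3 (0.00 log units; within the scatter) in this assay, and this is the only pair in the set that isolates the change. With the same atoms joined differently, the two methyl placements on the thiophene cannot be told apart by this read-out. No supporting data bear on why the two readings coincide.

Still open, as far as these compounds go, is how an unsubstituted thiophen-2-yl would read at this carbonyl carbon. Also open, from the compounds shown here alone, is whether a thiophene carrying an amine or a carboxylic acid in place of the methyl would stay level with compound 1 and compound 3.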